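Swapping phenyl for cyclohexyl on a weak inhibitor

The source may report more compounds than this note shows. Statements on the series, on what has been measured and on what is new or still open speak of the compounds shown alone.

In a functional assay on cells (Homo sapiens) for inhibition (on this read-out higher numbers stand for weaker inhibition and lower numbers for stronger inhibition), the measured compounds read as follows:
compound 1 `O=C(/C=C\N(O)Cc1ccccc1)c1ccc2ccccc2c1` gives 5400 nM
compound 2 `CC(=O)ON(/C=C\C(=O)c1ccc(F)cc1)Cc1ccccc1` gives > 10000 nM
compound 3 `O=C(/C=C\N(O)c1ccccc1)c1ccc(F)cc1` gives > 10000 nM

Compound 3 gives > 10000 nM as a limit of the assay, not as a number. Compound 2 also gives > 10000 nM as a limit. Compound 3 therefore shares the limit of > 10000 nM in this assay, at which 2 of the 3 values shown sit, and has no exact position of its own.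

The next compound to be tested is compound 4 `O=C(/C=C\N(O)C1CCCCC1)c1ccc(F)cc1` and it differs from compound 3 in one group. The change is cyclohexyl in place of phenyl on an amine nitrogen. Both groups are six-membered carbon rings, but only phenyl is aromatic.

For the measured compounds named here, no two measured compounds differ in just one place, so the effect of a single swap has not been seen here. Going by the values given here, the only exact reading comes from compound 1 at 5400 nM and it offers a rough guide to where a measurable member of this set might fall. In this assay the estimated change an at least 1.2-fold lower number from compound 3 to compound 4 (0.09 log units; that floor lies within the scatter) is expected to be small, leaning if anything toward stronger inhibition, and another limit would be no surprise. Compound 4 is estimated at 8000 nM (expected range 2500 nM to 25000 nM).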

Compound 4, half-maximal inhibitory concentration: > 10000 nM
Compound 4: no number, only a limit (the forecaster's own chance of this, stated with the estimate: 60%); at least 1.2-fold (0.09 log units) between middle value and limit.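

In this assay compound 4 gives > 10000 nM, which is a limit and not a number. Compound 3 also gives only a limit, so no step can be read between compound 3 and compound 4. Both share one reading: the limit of > 10000 nM in this assay, at which 3 of the 4 values shown sit.

From the compounds shown here alone, whether phenyl or cyclohexyl on the amine nitrogen gives stronger inhibition, and by how much, stays open.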